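From sulfanyl to hydroxy: expected cell tolerance of compound 4

The compounds below may be only part of what the source reports. "The series", "measured", "known", "first", "only" and "open" are said of these compounds alone.

Measured so far in an ADME assay on cells (Homo sapiens) for cytotoxicity, read by resazurin assay, with a stated time of 5 days (a lower number here means that less compound is tolerated, a higher number that more compound is tolerated), are three compounds:
- Compound 1 `COc1ccc(-c2nc(CC(=O)c3cccc(Cl)c3)nc3ccsc23)cn1` gives 30000 nM as a number
- Compound 2 `COc1ccc(-c2nc(COc3cccc(Cl)c3)nc3ccsc23)cn1` gives > 50000 nM as a limit
- Compound 3 `COc1ccc(-c2nc(CSCc3cccc(Cl)c3)nc3ccsc23)cn1` gives > 50000 nM as a limit

Compound 3 stands at the limit of > 50000 nM in this assay, at which 2 of the 3 values shown sit, and therefore has a limit and no number. The change to compound 4 `COc1ccc(-c2nc(CC(O)c3cccc(Cl)c3)nc3ccsc23)cn1` is (3-chlorophenyl)(hydroxy)methyl in place of (3-chlorobenzyl)sulfanyl on a saturated chain carbon bound to an aromatic carbon and places (3-chlorophenyl)(hydroxy)methyl in place of (3-chlorobenzyl)sulfanyl on a saturated chain carbon bound to an aromatic carbon.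

Going by the values given here, three measured steps concern this same place. With 3-chlorophenoxy in place of (3-chlorophenyl)carbonyl the data show an at least 1.6-fold higher number from compound 1 to compound 2 (0.22 log units; that floor lies within the scatter) and with (3-chlorobenzyl)sulfanyl in its place they show an at least 1.6-fold higher number from compound 1 to compound 3 (0.22 log units; that floor lies within the scatter) as well. The two limits leave a step that the two limits leave unreadable from compound 2 to compound 3 without a usable size.

Of the measured groups, the (3-chlorophenyl)carbonyl of compound 1 at 30000 nM comes closest to the entering group. The expected result is an at least 1.2-fold lower number from compound 3 to compound 4 (0.09 log units; that floor lies within the scatter) in this assay and this would be a small move toward a lower number or none beyond the scatter. The estimate for compound 4 is 40000 nM with an expected range from 20000 nM to 70000 nM in all.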

Compound 4, half-maximal cytotoxic concentration: 31000 nM
Compound 4: the middle estimate sits 1.3-fold (0.11 log units) above what was measured; the measured number falls inside the stated range.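

In this assay, (3-chlorophenyl)(hydroxy)methyl in place of (3-chlorophenyl)carbonyl gives a 1.0-fold higher number from compound 1 to compound 4 (0.01 log units; within the scatter), so on this saturated chain carbon bound to an aromatic carbon, the two groups cannot be told apart and this place now has a second measured number. Against the other two groups the data give an at least 1.6-fold lower number from compound 3 to compound 4 (0.20 log units; that floor lies within the scatter) and an at least 1.6-fold lower number from compound 2 to compound 4 (0.20 log units; that floor lies within the scatter). Both floors lie within the scatter, and they do not set compound 4 apart from either compound. Compound 2 and compound 3 each carry a limit and not a number: the limit of > 50000 nM in this assay, at which 2 of the 4 values shown sit.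

As far as these compounds go, how far compound 2 and compound 3 truly lie from compound 4 remains unknown. From the compounds shown here alone, whether an amine, a carboxylic acid or a longer chain in this place would give a number or a limit also stays open.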